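This account rests on a few compounds, and the source may have more. Where it says the series, first, only, none or still open, it means among the compounds named here.

Compound 1 `Cc1nsc(-c2ccc(N3CCN(c4cccc(Cl)c4)CC3)nn2)n1`: 0.6 nM
Compound 2 `Cc1nsc(-c2ccc(N3CCN(c4cccc(C(F)(F)F)c4)CC3)nc2)n1`: 5 nM
Compound 3 `Cc1nsc(-c2ccc(N3CCN(c4cccc(C(F)(F)F)c4)CC3)cc2)n1`: 10 nM

In a functional assay (aorta) for inhibition, with Rattus norvegicus as the target, with a stated time of 8 days (a lower number here means a stronger inhibitor, a higher number a weaker inhibitor), compound 1 has the lowest number of the three, and its gaps to compound 2 and compound 3 both lie beyond the usual scatter. Compound 4 `Cc1nsc(-c2ccc(N3CCN(c4cccc(C(F)(F)F)c4)CC3)nn2)n1` keeps the core of compound 1 but has trifluoromethyl in place of chloro on an aromatic carbon. Among the compounds with values here, no measured pair isolates this change. Compound 2 at 5 nM and compound 3 at 10 nM carry trifluoromethyl on other cores and offer only indirect guidance. A modest rise toward a higher number is expected, with an estimated step (a 2.5-fold higher number from compound 1 to compound 4 (0.40 log units; beyond the scatter)). Compound 4 is estimated at 1.5 nM (expected range 0.4 nM to 6 nM).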

Compound 4, half-maximal inhibitory concentration: 0.3 nM
Compound 4: middle estimate off by 5.0-fold (0.70 log units), on the high side; the whole stated range lies above it.
By their numbers in this assay, from the lowest: compounds 4 and 1 (each within the scatter of the next); then compounds 2 and 3 (each within the scatter of the next).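

In this assay, within the data shown here, the one pair that differs only at this aromatic carbon gives a 2.0-fold lower number from compound 1 to compound 4 (0.30 log units; within the scatter), so on the core of compound 1, trifluoromethyl in place of chloro cannot be told apart from chloro. The four heavy atoms of trifluoromethyl, against the one of chloro, bring no change beyond the scatter here. No measured evidence bears on why this is so. From the compounds shown here alone, it remains open whether a nitrile, a methoxy group or an amine on this carbon would give a similar number, and whether chloro and trifluoromethyl also match on the cores of compound 2 and compound 3.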